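Replacing an Amide with an Ether on the Fused Core

The source may hold more compounds than are shown below. What is called first, only, known or untested is meant among the compounds shown, and "the series" means these compounds.

Compound 1 `Cc1nn(-c2ncnc3nc[nH]c23)c2c1C(C(=O)N(C)c1nccs1)CC(=O)N2`: 3300 nM
Compound 2 `Cc1nn(-c2ncnc3nc[nH]c23)c2c1C(OCc1ccc(F)cc1)CC(=O)N2`: 126 nM
Compound 3 `Cc1nn(-c2ncnc3nc[nH]c23)c2c1C(C(=O)N(C)c1ccccc1)CC(=O)N2`: 5220 nM

In a functional assay on HEK293 cells for agonist activity at G-protein coupled receptor 39 (Homo sapiens), read by scintillation proximity assay and inositol phosphate accumulation, with a stated time of 75 min (a higher number here means that more compound is needed for the effect, a lower number that less compound is needed), compound 3 gives 5220 nM, the highest of the three numbers. Compound 1 lies nearest, and a 1.6-fold higher number from compound 1 to compound 3 (0.20 log units; within the scatter). Compound 2 lies furthest, and a 41-fold higher number from compound 2 to compound 3 (1.62 log units; beyond the scatter). Compound 4 `Cc1nn(-c2ncnc3nc[nH]c23)c2c1C(OCCn1cccn1)CC(=O)N2` has not yet been measured. The change from compound 3 to compound 4 is 2-(1H-pyrazol-1-yl)ethoxy in place of methyl(phenyl)carbamoyl on a saturated ring carbon. Going by the values given here, two measured steps bear on it, each exchanging a carbamoyl group and an ether-linked group at the same saturated ring carbon: a 26-fold lower number from compound 1 to compound 2 (1.42 log units; beyond the scatter) and a 41-fold higher number from compound 2 to compound 3 (1.62 log units; beyond the scatter). Compound 4 keeps the ether link, but its pyrazole-bearing chain is not the (4-fluorobenzyl)oxy of compound 2, which gave 126 nM, so the full size of that change need not carry over. For compound 4 the expected step is a 13-fold lower number from compound 3 to compound 4 (1.12 log units; beyond the scatter). For compound 4 the estimate in this assay is 400 nM, with a range from 100 nM to 1600 nM.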

Compound 4, half-maximal effective concentration: 2270 nM
Compound 4: middle estimate off by 5.7-fold (0.75 log units), on the low side, and the stated range ends below it.
By their numbers in this assay, from the lowest: compound 2; then compounds 4, 1 and 3 (each within the scatter of the next, the first and the last beyond it).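

In this assay, the ether link at this saturated ring carbon does not by itself bring the gain seen earlier: replacing the amide-type groups with 2-(1H-pyrazol-1-yl)ethoxy gives only a 2.3-fold lower number from compound 3 to compound 4 (0.36 log units; beyond the scatter), and a 1.5-fold lower number from compound 1 to compound 4 (0.16 log units; within the scatter) leaves no clear separation from the thiazole amide. With the oxygen link kept, the group it carries matters greatly, as shown by an 18-fold higher number from compound 2 to compound 4 (1.26 log units; beyond the scatter), so the low number of compound 2 belongs to (4-fluorobenzyl)oxy as a whole and not to the ether alone. Nothing available explains this difference between the two ether-linked groups.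

The compounds shown leave open whether the ring or the chain length separates compound 2 from compound 4, as both change together. They also do not show how a morpholine or a carboxylic acid in place of the pyrazole would behave on this ether chain.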